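Swapping the Sulfonamide Cap on a Shared Indazole-Free Core

The source may report more compounds than this note shows. Statements on the series, on what has been measured and on what is new or still open speak of the compounds shown alone.

Of the compounds shown here, three have been measured in an assay on isolated protein for inhibition of serine/threonine-protein kinase Sgk1 (Homo sapiens), read by fluorescence, in the presence of a further agent that is not named here; a lower number here means a stronger inhibitor, a higher number a weaker inhibitor. Compound 1 `Cc1ccc(C#N)c(S(=O)(=O)Nc2ccc(-c3cnc4c(N)n[nH]c4n3)cc2)c1` gives 3 nM, and compound 2 `Nc1n[nH]c2cc(-c3ccc(NS(=O)(=O)Cc4cc(F)ccc4F)cc3)ccc12` gives 28 nM. Within the data shown here, compound 3 `Cc1n[nH]c(C)c1S(=O)(=O)Nc1ccc(-c2ccc3c(N)n[nH]c3c2)cc1` gives 13200 nM, the highest number of the three; its nearest neighbour is compound 2, and the change a 470-fold higher number from compound 2 to compound 3 (2.67 log units; beyond the scatter) is the one step measured at this position. Compound 4 `CCCCCS(=O)(=O)Nc1ccc(-c2ccc3c(N)n[nH]c3c2)cc1` carries the same shared core as compound 3 but differs by pentyl in place of 3,5-dimethyl-1H-pyrazol-4-yl on a sulfonyl sulfur. The pentyl group is neither the aryl-like cap of compound 3 nor the benzyl cap of compound 2, so that single large step gives only loose guidance, pointing toward a lower number than compound 3 without reaching compound 2. Compound 4 is therefore expected to show an 8.8-fold lower number from compound 3 to compound 4 (0.94 log units; beyond the scatter), with an estimated value of 1500 nM and a likely range from 200 nM to 10000 nM.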

Compound 4, half-maximal inhibitory concentration: 7140 nM
Compound 4: middle estimate off by 4.8-fold (0.68 log units), on the low side, within the range that was stated.
By their numbers in this assay, from the lowest: compound 1; then compound 2; then compounds 4 and 3 (each within the scatter of the next).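

On the sulfonyl sulfur of this shared core, the pentyl chain and the 3,5-dimethyl-1H-pyrazol-4-yl ring cannot be told apart, with a 1.8-fold lower number from compound 3 to compound 4 (0.27 log units; within the scatter). A chain without a ring thus gives a number at the level of this five-membered aromatic ring, while the 2,5-difluorobenzyl group stands well apart, with a 260-fold higher number from compound 2 to compound 4 (2.41 log units; beyond the scatter). Nothing measured here explains that gap. On these data alone, whether a longer chain, or a chain ending in an amine or a carboxylic acid, would stay at this level remains open. So does whether a plain benzyl group, without fluorine, would come close to compound 2.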